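The compounds below may be only part of what the source reports. "The series", "measured", "known", "first", "only" and "open" are said of these compounds alone.

The three measured compounds in a functional assay on A549 cells (Homo sapiens) for inhibition, read by MTT assay, with a stated time of 72 h (on this read-out higher numbers stand for weaker inhibition and lower numbers for stronger inhibition), are:

Compound 1 `COc1cc2c(Oc3ccc(NC(=O)c4nn(-c5ccccc5C)c(=O)cc4C)cc3F)ccnc2cc1OCCCN1CCCC1`: 1300 nM
Compound 2 `COc1cc2c(Oc3ccc(NC(=O)c4nn(-c5ccccc5C)c(=O)cc4C)cc3F)ccnc2cc1OCCCN1CCCCC1`: 1920 nM
Compound 3 `COc1cc2c(Oc3ccc(NC(=O)c4nn(-c5ccccc5C)c(=O)cc4C)cc3F)ccnc2cc1OCCCN1CCN(C)CC1`: 2830 nM

Compound 1 gives the lowest number of the three. Its nearest neighbour is compound 2, with a 1.5-fold higher number from compound 1 to compound 2 (0.17 log units; within the scatter), and its furthest is compound 3, with a 2.2-fold higher number from compound 1 to compound 3 (0.34 log units; beyond the scatter). Between the other two the gap is a 1.5-fold higher number from compound 2 to compound 3 (0.17 log units; within the scatter).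

Compound 4 `COc1cc2c(Oc3ccc(NC(=O)c4nn(-c5ccc(Cl)cc5)c(=O)cc4C)cc3F)ccnc2cc1OCCCN1CCCC1` keeps the whole of compound 1 apart from one change: 4-chlorophenyl in place of 2-methylphenyl on an aromatic nitrogen. Within the data shown here, none of the measured steps touches this part of the molecule. All three of them exchange the amine at the end of the chain on the core of compound 1, and all three are small, two of them inside the scatter and one modestly beyond it. They therefore give no guidance on the direction of the present change, only a hint that this series moves within a narrow band. Compound 4 is accordingly expected to land near compound 1, with a 1.2-fold higher number from compound 1 to compound 4 (0.06 log units; within the scatter), and the range is left wide to reflect the absence of any bearing step. The estimate for compound 4 in this assay is 1500 nM, expected to fall between 500 nM and 4500 nM.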

Compound 4, half-maximal inhibitory concentration: 230 nM
For compound 4 the middle estimate is 6.5-fold (0.81 log units) above the measured one; measured number outside the range, below it.
By their numbers in this assay, from the lowest: compound 4; then compounds 1, 2 and 3 (each within the scatter of the next, the first and the last beyond it).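

In this assay the group on the aromatic nitrogen proves to be a more sensitive point than the amine at the end of the chain: 4-chlorophenyl in place of 2-methylphenyl gives a 5.7-fold lower number from compound 1 to compound 4 (0.75 log units; beyond the scatter) and so exceeds the largest amine exchange, a 2.2-fold higher number from compound 1 to compound 3 (0.34 log units; beyond the scatter). The earlier compounds shown here varied only the amine and left this position untouched, so they could not show that the number responds to it, or that it can move downward from that of compound 1 on the shared core. Nothing among the data given accounts for the step, which stands as an observation without an explanation.

The step changes both the atom on the phenyl ring and its place there, so the compounds shown leave open whether the chlorine or its position carries the effect, a question that 2-chlorophenyl, 4-methylphenyl and plain phenyl at this nitrogen would help to separate. They also leave open whether 4-chlorophenyl brings a similar step when the chain ends in piperidin-1-yl or 4-methylpiperazin-1-yl instead of pyrrolidin-1-yl.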